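The source may report more compounds than this note shows. Statements on the series, on what has been measured and on what is new or still open speak of the compounds shown alone.

Compound 2 `O=S(=O)(Nc1ccc(-c2nc3ccccc3o2)cc1)c1ccccc1O` stands at the edge of what an assay on isolated protein for inhibition of malate dehydrogenase, mitochondrial (Sus scrofa), with stated times of 45 min and 30 min (on this read-out lower numbers stand for stronger inhibition and higher numbers for weaker inhibition), reports: compound 2 gives > 63000 nM, a limit of the assay and not a number. Compound 1 `COc1ccccc1S(=O)(=O)Nc1ccc2oc(-c3ccccc3)nc2c1` gives > 63000 nM, likewise a limit. Compound 3 `O=S(=O)(Nc1ccc2oc(-c3ccccc3)nc2c1)c1ccccc1O` gives > 63000 nM, again a limit. All three values rest on (the limit of > 63000 nM in this assay, at which 3 of the 3 values shown sit). Within the data shown here, the single one-place step, a step that the two limits leave unreadable from compound 1 to compound 3, runs between two limits and so tells nothing of size or direction. Compound 4 `O=S(=O)(Nc1ccc(-c2nc3ccccc3o2)cc1)c1ccc(Cl)c(Cl)c1` differs from compound 2 by 3,4-dichlorophenyl in place of 2-hydroxyphenyl on a sulfonyl sulfur. No measured step bears on this change, so nothing can be read from the shown values about its size; no step beyond the scatter is expected in this assay. The expected step is a step that the limit leaves unreadable from compound 2 to compound 4. Compound 4 is estimated at 80000 nM, between 15000 nM and 300000 nM, most likely once more reported only as a limit.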

Compound 4, half-maximal inhibitory concentration: > 63000 nM
Compound 4: no number, only a limit; the forecaster's own chance of this, stated with the estimate: 70%; the middle value lies beyond the limit too.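

In this assay compound 4 gives > 63000 nM, a limit and not a number. The step from compound 2 to compound 4 cannot be read, as both values are limits: the limit of > 63000 nM in this assay, at which 4 of the 4 values shown sit.

The compounds shown leave open whether any change to this series gives a readable number in this assay.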